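A few compounds are considered here, and "the series" means these few. Any claim that something is new, unique, unknown or untested is made for them only; others in the source may bear on it.

For the measured compounds named here, compound 2 `O=C(O)c1cccc(CNc2cc(C(F)(F)F)cc3[nH]ncc23)c1` gives 81% in an assay for inhibition of Tryptophan 2,3-dioxygenase (Homo sapiens), with stated times of 10 min and 60 min, tested at 10 uM (a lower number here means a weaker effect, a higher number a stronger effect of the compound at the concentration tested), the lowest of the three numbers known; compound 1 `O=[N+]([O-])c1cc(Cl)ccc1CNc1cc(C(F)(F)F)cc2[nH]ncc12` gives 90%, which lies within the scatter of compound 2, while compound 3 `O=[N+](O)c1c(Cl)cccc1CNc1cc(C(F)(F)F)cc2[nH]ncc12` gives 96%, a gap beyond the scatter. Compound 4 `Nc1cccc(CNc2cc(C(F)(F)F)cc3[nH]ncc23)c1` differs from compound 2 in one respect: amino in place of carboxy on an aromatic carbon. Going by the values given here, no pair of measured compounds isolates this change, so nothing shows directly how it bears on this assay. Since every measured compound sits high, compound 4 is expected to stay in the same region, and the step of a number 7 percentage points lower from compound 2 to compound 4 (within the scatter) is expected to be small, if anything slightly downward and not clearly beyond the scatter. Compound 4 is accordingly estimated at 74%, with a range from 50% to 92%.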

Compound 4, a percentage reported as inhibition, at one concentration (the size of the read-out at that concentration, not a potency): 68%
Compound 4: the middle estimate sits 6 percentage points above what was measured; low and high end bracket the measured number.
By their numbers in this assay, from the lowest: compound 4; then compounds 2, 1 and 3 (each within the scatter of the next, the first and the last beyond it).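

Carboxy and amino on this aromatic carbon, meta to a large group, form the only pair here that isolates a single change, and in this assay the exchange gives a number 13 percentage points lower from compound 2 to compound 4 (beyond the scatter) as a modest step. The position is therefore not indifferent to the group it carries, though the step rests on this one pair. No measurement at hand accounts for the step.

As far as these compounds go, whether a methoxy group or a primary amide at this place would stay with carboxy or with amino remains open. From the compounds shown here alone, whether a methylene spacer before the amino group would alter the step also remains open.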